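A few compounds are considered here, and "the series" means these few. Any claim that something is new, unique, unknown or untested is made for them only; others in the source may bear on it.

In an assay on cells for agonist activity at vitamin D3 receptor (Homo sapiens), with a stated time of 96 h (on this read-out lower numbers stand for an effect already at smaller amounts and higher numbers for an effect only at larger amounts of compound), compound 1 `CCn1c(C(=O)NCCCN(C)C)ccc1C(CC)(CC)c1ccc(OCCC(O)(CC)CC)c(C)c1` gives 5 nM, the lowest of the two numbers shown. Compound 2 `CCn1c(C(=O)NCCN(C)C)ccc1C(CC)(CC)c1ccc(OCCC(O)(CC)CC)c(C)c1` gives 82 nM, so a 16-fold higher number from compound 1 to compound 2 (1.21 log units; beyond the scatter). Compound 3 `C=CCN(C)C(=O)c1ccc(C(CC)(CC)c2ccc(OCCC(O)(CC)CC)c(C)c2)n1CC` reaches only the limit of the assay at > 10000 nM. That limit appears as an at least 2000-fold higher number from compound 1 to compound 3 (3.30 log units; beyond the scatter) and as an at least 120-fold higher number from compound 2 to compound 3 (2.08 log units; beyond the scatter). Compound 4 `C#CC(C)OC(=O)c1ccc(C(CC)(CC)c2ccc(OCCC(O)(CC)CC)c(C)c2)n1CC` carries a change of the same kind: (1-methylprop-2-yn-1-yl)oxy in place of (3-(dimethylamino)propyl)amino on a carbonyl carbon. Because an at least 2000-fold higher number from compound 1 to compound 3 (3.30 log units; beyond the scatter) and an at least 120-fold higher number from compound 2 to compound 3 (2.08 log units; beyond the scatter) both followed removal of the dimethylamino chain from the carbonyl carbon, and compound 4 lacks that chain as well, a large rise in the number is expected, a 1600-fold higher number from compound 1 to compound 4 (3.20 log units; beyond the scatter). For compound 4 the estimate is 8000 nM, expected within a range from 800 nM to 80000 nM, with a fair chance that only a limit is reported.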

Compound 4, half-maximal effective concentration: 2650 nM
Compound 4: the middle estimate sits 3.0-fold (0.48 log units) above what was measured; low and high end bracket the measured number.
By their numbers in this assay, from the lowest: compound 1; then compound 2; then compound 4. At a limit, above all of these: compound 3.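

With (1-methylprop-2-yn-1-yl)oxy on the carbonyl carbon, compound 4 stays far behind both compounds that carry a dimethylamino chain, with a 530-fold higher number from compound 1 to compound 4 (2.72 log units; beyond the scatter) and a 32-fold higher number from compound 2 to compound 4 (1.51 log units; beyond the scatter). Even so, this group does better than allyl(methyl)amino in the same place, with an at least 3.7-fold lower number from compound 3 to compound 4 (0.57 log units; beyond the scatter). Compound 3 stands at a limit, so that step is a bound only: the limit of > 10000 nM in this assay, at which 1 of the 4 values shown sits.

Still open, going by these compounds, is how a (3-(dimethylamino)propyl)oxy group would compare. It would keep the chain but join it through oxygen, showing whether the amide nitrogen matters as well as the dimethylamino end.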